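The source may hold more compounds than are shown below. What is called first, only, known or untested is meant among the compounds shown, and "the series" means these compounds.

Compound 1 `COc1cc(-c2nnc3n2NC(c2ccco2)C(C(=O)c2ccc(Br)cc2)S3)cc(OC)c1OC` belongs to a small series sharing one core and was examined in a functional assay on MCF7 cells (Homo sapiens) for cytotoxicity, read by MTT assay, with a stated time of 48 h; on this read-out higher numbers stand for weaker inhibition and lower numbers for stronger inhibition. In this assay compound 1 gives > 100000 nM, which is a limit of the assay rather than a number. Compound 2 `COc1cc(-c2nnc3n2NC(c2ccco2)C(C(=O)c2ccc(F)cc2)S3)cc(OC)c1OC` carries fluoro in place of bromo on an aromatic carbon; in this assay compound 2 gives > 100000 nM, again only a limit. Compound 3 `COc1ccc(C(=O)C2Sc3nnc(-c4cc(OC)c(OC)c(OC)c4)n3NC2c2ccco2)cc1` carries methoxy in place of bromo on an aromatic carbon; in this assay compound 3 gives > 100000 nM, also a limit. The three steps among them, a step that the two limits leave unreadable from compound 1 to compound 2, a step that the two limits leave unreadable from compound 1 to compound 3 and a step that the two limits leave unreadable from compound 2 to compound 3, therefore cannot be sized, as the limit of > 100000 nM in this assay, at which 3 of the 3 values shown sit, makes clear. Compound 4 `COc1cc(-c2nnc3n2NC(c2ccco2)C(C(=O)c2ccc(C(F)(F)F)cc2)S3)cc(OC)c1OC` has not yet been measured. It differs from compound 1 thus: trifluoromethyl in place of bromo on an aromatic carbon. Within the data shown here, the two exchanges of bromo already measured bear most closely on this one, yet their size is unreadable, and nothing among the measured compounds points to a readable change. The expected step is a step that the limit leaves unreadable from compound 1 to compound 4, none beyond the scatter. Compound 4 is accordingly estimated to give 150000 nM, within 50000 nM to 500000 nM.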

Compound 4, half-maximal inhibitory concentration: 33600 nM
Estimate against measurement, compound 4: 4.5-fold (0.65 log units) above, outside the stated range (below it).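

In this assay, the exchange at this aromatic carbon, para to a large group, now gives a readable result: trifluoromethyl in place of bromo yields an at least 2.9-fold lower number from compound 1 to compound 4 (0.47 log units; beyond the scatter). The other two groups measured at this carbon give the same picture, with an at least 2.9-fold lower number from compound 3 to compound 4 (0.47 log units; beyond the scatter) and an at least 2.9-fold lower number from compound 2 to compound 4 (0.47 log units; beyond the scatter). Of the four groups shown here, only trifluoromethyl gives a value that is a number rather than a limit, and the steps among the other three still cannot be read: the limit of > 100000 nM in this assay, at which 3 of the 4 values shown sit.

On these data alone, the true size of each new step remains open, as each one starts from a limit. Also open, as far as these compounds go, is whether another group at this carbon, such as a nitrile, a carboxylic acid or an amine, would give a lower number than trifluoromethyl does.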